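A Chlorine Added to the Phenyl of Compound 2

The source may hold more compounds than are shown below. What is called first, only, known or untested is meant among the compounds shown, and "the series" means these compounds.

Two measured compounds share one core. Compound 1 `CC(C)[C@@H]1CC[C@@H](C)C[C@@]12N(C)C(=O)[C@@H]1[C@H]3C(=O)N(C)C(=O)[C@H]3ON12` carries a methyl on an amide-type nitrogen in a ring, and in a functional assay, read by spectrophotometry, with a stated time of 2 h, tested at 0.5 mg/mL (on this read-out higher numbers stand for a stronger effect at the one concentration tested and lower numbers for a weaker effect), compound 1 gives 36.5%. Compound 2 `CC(C)[C@@H]1CC[C@@H](C)C[C@@]12N(C)C(=O)[C@@H]1[C@H]3C(=O)N(c4ccccc4)C(=O)[C@H]3ON12` carries a phenyl in that place, and in this assay compound 2 gives 28.7%. Set against compound 1, the step of a number 7.8 percentage points lower from compound 1 to compound 2 (within the scatter) lies within the scatter, so the two stand level as far as this assay can tell. Compound 3 `CC(C)[C@@H]1CC[C@@H](C)C[C@@]12N(C)C(=O)[C@@H]1[C@H]3C(=O)N(c4ccc(Cl)cc4)C(=O)[C@H]3ON12` is not yet measured; it differs from compound 2 by chloro in place of hydrogen on an aromatic carbon. Among the measured compounds shown here, no measured step involves a chloro group, so only the one phenyl-for-methyl step stands nearby, and it changed nothing beyond the scatter. The step to compound 3 is therefore expected to be a number 1.3 percentage points higher from compound 2 to compound 3 (within the scatter), nothing beyond the scatter. The estimate for compound 3 in this assay is 30%, between 15% and 45%.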

Compound 3, a percentage reported as activity, at one concentration (the size of the read-out at that concentration, not a potency): 47.5%
The estimate for compound 3 lay 17.5 percentage points below the measured number; measured number above the stated range.
By their numbers in this assay, from the lowest: compounds 2 and 1 (each within the scatter of the next); then compound 3.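

On a six-membered aromatic ring of carbon only, para to a large group, chloro in place of hydrogen gives a number 18.8 percentage points higher from compound 2 to compound 3 (beyond the scatter) in this assay, so a single added atom at this position moves the read-out beyond the scatter. The swap of methyl for plain phenyl on the ring nitrogen stayed within the scatter, yet 4-chlorophenyl in place of methyl gives a number 11 percentage points higher from compound 1 to compound 3 (beyond the scatter), which shows that this nitrogen position can tell groups apart once the chloro is present. Nothing available here accounts for the rise.

From the compounds shown here alone, whether the rise belongs to chloro alone, or would also appear with bromo, methoxy or an amine at the same place on the ring, stays open. Also open is whether the order of these compounds would hold at other concentrations, since each number comes from one concentration and is not a potency.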